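The compounds below may be only part of what the source reports. "The series", "measured", "known", "first", "only" and "open" are said of these compounds alone.

Among the measured compounds shown here, only two compounds have been tested so far in a functional assay on RAW264.7 cells (Mus musculus) for inhibition, read by Griess assay, with stated times of 2 h and 18 h; a higher number here means a weaker inhibitor, a lower number a stronger inhibitor. Compound 1 `CC(=O)O[C@@H]1CC[C@]2(C)C(CCC3=CCOC3=O)=C(C)C(=O)[C@@H](O)[C@H]2C1(C)C` gives > 50000 nM, which is a limit of the assay and not a number. Compound 2 `COC(OC)[C@@]1(C)CCC[C@@]2(C)[C@H]1CC=C(C)[C@@H]2CC/C(C)=C/CO` gives > 50000 nM, which is also a limit. Compound 2 therefore has no exact number of its own, and the whole picture so far is the limit of > 50000 nM in this assay, at which 2 of the 2 values shown sit.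

Compound 3 `CC1=CC[C@H]2[C@@](C)(CO)CCC[C@]2(C)[C@H]1CC/C(C)=C/CO` differs from compound 2 by carrying hydroxymethyl in place of dimethoxymethyl on a saturated ring carbon. For the measured compounds named here, no measured pair shows what this exchange does in this assay, so any expectation is uncertain. A small move towards stronger inhibition is expected, and the estimated step of an at least 1.2-fold lower number from compound 2 to compound 3 (0.09 log units; that floor lies within the scatter) may not go beyond the scatter. The expected value for compound 3 is 40000 nM, with an estimated range from 15000 nM to 80000 nM.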

Compound 3, half-maximal inhibitory concentration: 33400 nM
The estimate for compound 3 lay 1.2-fold (0.08 log units) above the measured number; the range from low to high includes it.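

Among the compounds shown here, compound 3 is the first compound in this assay to give an exact number and not a limit, so the saturated ring carbon that carries this group now has a measured reading. Exchanging dimethoxymethyl for hydroxymethyl at this position gives an at least 1.4-fold lower number from compound 2 to compound 3 (0.17 log units; that floor lies within the scatter), so the printed step is only a floor and that floor does not clear the usual scatter. The true size of the step stays unknown because the other side of the comparison is a limit and not a number: the limit of > 50000 nM in this assay, at which 2 of the 3 values shown sit.

The compounds shown leave open how a carboxylic acid, an aminomethyl group or a plain methyl group would read at this same position. They also leave open whether hydroxymethyl would give a similar step on the core of compound 1.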